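The source may report more compounds than this note shows. Statements on the series, on what has been measured and on what is new or still open speak of the compounds shown alone.

The measured compounds, with their solubility readings:

Compound 1, `Cn1ccc2ccc(-c3cc(Nc4ccccc4S(N)(=O)=O)cc4nccnc34)cc21`: 6 ug/mL
Compound 2, `CN(C)S(=O)(=O)c1ccccc1Nc1cc(-c2ccc3ccn(C)c3c2)c2nccnc2c1`: 2 ug/mL
Compound 3, `Cn1cc(CNC(=O)c2ccncc2Nc2cc(-c3ccc4ccn(C)c4c3)c3nccnc3c2)cn1`: 127 ug/mL

In a physicochemical assay for solubility, read by spectrophotometry, measured as kinetic solubility, at pH 8, tested at 500 uM (a lower number here means a less soluble compound, a higher number a more soluble compound), compound 3 stands highest of the three, with compound 1 the nearest and compound 2 the furthest from it, both gaps beyond the scatter. Compound 4, `CC(=O)N1CC(CNC(=O)c2ccncc2Nc2cc(-c3ccc4ccn(C)c4c3)c3nccnc3c2)C1`, has not yet been measured. It differs from compound 3 in one place: 1-acetylazetidin-3-yl in place of 1-methyl-1H-pyrazol-4-yl on a saturated chain carbon bound to an amide-type nitrogen.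

Within the data shown here, the only measured step, a 3.0-fold lower number from compound 1 to compound 2 (0.48 log units; beyond the scatter), concerns a change on a sulfonyl sulfur in a different part of the molecule and does not touch the carbamoyl chain that is altered here. Among the measured compounds shown here, no measured pair shows what exchanging 1-methyl-1H-pyrazol-4-yl for 1-acetylazetidin-3-yl on a saturated chain carbon bound to an amide-type nitrogen does in this assay. With nothing that bears directly on the change, the expectation for compound 4 is a step of no more than the scatter in either direction from compound 3, so that a 1.1-fold lower number from compound 3 to compound 4 (0.02 log units; within the scatter) is expected to be small. Compound 4 is therefore estimated at 120 ug/mL, with a likely range from 50 ug/mL to 250 ug/mL.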

Compound 4, solubility: 252 ug/mL
Beside the measured number, compound 4's estimate is 2.1-fold (0.32 log units) below it; measured number outside the range, above it.
By their numbers in this assay, from the lowest: compound 2; then compound 1; then compounds 3 and 4 (each within the scatter of the next).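

In this assay, among these compounds, exchanging 1-methyl-1H-pyrazol-4-yl for 1-acetylazetidin-3-yl on a saturated chain carbon bound to an amide-type nitrogen gives a 2.0-fold higher number from compound 3 to compound 4 (0.30 log units; within the scatter), and this is the first reading of any change at this place in the molecule. The place therefore holds either a five-membered aromatic ring with 2 hetero atoms or a four-membered non-aromatic ring with 1 hetero atom, and this pair shows no step beyond the scatter, although the step lies at the edge of it. Nothing available accounts for this reading in terms of either group.

As far as these compounds go, whether an amine, a carboxylic acid or a longer chain in place of 1-acetylazetidin-3-yl would give a step beyond the scatter in this assay remains open. This one pair also cannot separate the ring size, the loss of the aromatic ring and the added double bond outside aromatic rings, since all of these change together from compound 3 to compound 4.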